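The source may report more compounds than this note shows. Statements on the series, on what has been measured and on what is new or still open speak of the compounds shown alone.

Measured so far in a functional assay on MDA cells (Homo sapiens) for inhibition, read by MTT assay, with a stated time of 48 h; on this read-out higher numbers stand for weaker inhibition and lower numbers for stronger inhibition

- compound 1 `O=C(/C=C/COc1no[n+]([O-])c1S(=O)(=O)c1ccccc1)NO` gives 47700 nM
- compound 2 `O=C(NO)c1ccc(Oc2no[n+]([O-])c2S(=O)(=O)c2ccccc2)cc1` gives 6660 nM

Going by the values given here, only these two compounds have numbers so far. Compound 2 at 6660 nM holds the lower of the two, which marks it as the stronger inhibitor of the pair. Compound 1 at 47700 nM sits higher by a gap beyond the usual scatter. The next compound, compound 3 `COc1cc(C(=O)NO)ccc1Oc1no[n+]([O-])c1S(=O)(=O)c1ccccc1`, has not yet been tested in this assay and keeps the frame of compound 2 with one alteration. The difference is methoxy in place of hydrogen on an aromatic carbon in the sense of methoxy in place of hydrogen on an aromatic carbon, ortho to a large group and meta to a hydroxycarbamoyl group. Among the compounds with values here, no measured pair shows what such a replacement does here, and the two values in hand give no direction for it. A small change is therefore expected, with nothing beyond the scatter. The expected size of the move is a 1.1-fold higher number from compound 2 to compound 3 (0.02 log units; within the scatter) and is only an estimate. For compound 3 the estimated value is 7000 nM and a range from 2300 nM to 21000 nM is expected.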

Compound 3, half-maximal inhibitory concentration: 8020 nM
For compound 3 the middle estimate is 1.1-fold (0.06 log units) below the measured one, and the stated range covers the measured number.
By their numbers in this assay, from the lowest: compounds 2 and 3 (each within the scatter of the next); then compound 1.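

In this assay, putting methoxy in place of hydrogen on the aromatic carbon ortho to a large group and meta to a hydroxycarbamoyl group gives a 1.2-fold higher number from compound 2 to compound 3 (0.08 log units; within the scatter), so at this position the added group leaves the read-out indistinguishable from that of the parent compound. Going by these compounds alone, this pair is the first to differ in one place only, and it gives the first direct reading of a single replacement on this six-membered aromatic ring, which the earlier compounds could not provide. Nothing at hand accounts for this outcome.

The compounds shown leave open whether this tolerance extends to other groups at the same carbon, such as a fluorine atom, an amine or a longer alkoxy chain, or whether methoxy on another carbon of the ring would give a similar reading. They also do not tell what would happen to the read-out if a carboxylic acid stood in place of the hydroxycarbamoyl group on this frame.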